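Replacing 1,4-dioxan-2-yl with oxetan-2-yl in a sulfonamide series

A few compounds are considered here, and "the series" means these few. Any claim that something is new, unique, unknown or untested is made for them only; others in the source may bear on it.

Of the compounds shown here, three sharing one core have been measured in an ADME assay on MDCKII-LE cells (Canis lupus familiaris) for permeability, read by transwell migration, in the apical to basolateral direction (a lower number here means that the compound crosses the layer more slowly, a higher number that the compound crosses the layer faster), and they differ only in the ring on a saturated chain carbon bound to a sulfonamide nitrogen. Compound 1 `CC1(C)CO[C@H]1CN([C@H](CCC(F)(F)F)C(N)=O)S(=O)(=O)c1ccc(Cl)cc1`, with 3,3-dimethyloxetan-2-yl, gives 26.4 10^-6 cm/s. Compound 2 `NC(=O)[C@@H](CCC(F)(F)F)N(C[C@H]1CCCCO1)S(=O)(=O)c1ccc(Cl)cc1`, with oxan-2-yl, gives 13.4 10^-6 cm/s. Compound 3 `NC(=O)[C@@H](CCC(F)(F)F)N(C[C@H]1COCCO1)S(=O)(=O)c1ccc(Cl)cc1`, with 1,4-dioxan-2-yl, gives 20.6 10^-6 cm/s, which stands within the scatter of both other values.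

The next compound is compound 4 `NC(=O)[C@@H](CCC(F)(F)F)N(C[C@H]1CCO1)S(=O)(=O)c1ccc(Cl)cc1`, which has oxetan-2-yl in place of 1,4-dioxan-2-yl at that same place: oxetan-2-yl in place of 1,4-dioxan-2-yl on a saturated chain carbon bound to a sulfonamide nitrogen. Two measured ring swaps bear on this change in general terms: a 2.0-fold lower number from compound 1 to compound 2 (0.29 log units; within the scatter), and a 1.5-fold higher number from compound 2 to compound 3 (0.19 log units; within the scatter). The closest guide is the third swap, since compound 1 also carries an oxetan ring, though with its dimethyl substitution. For the measured compounds named here, no measured pair shows the effect of removing that substitution.

In this assay no step beyond the scatter is expected, because a 1.3-fold lower number from compound 1 to compound 3 (0.11 log units; within the scatter) is also a small step. The estimate amounts to a 1.1-fold lower number from compound 3 to compound 4 (0.04 log units; within the scatter), an expected step within the scatter. Compound 4 is expected at 19 10^-6 cm/s, with an estimated range of 10 10^-6 cm/s to 34 10^-6 cm/s.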

Compound 4, apparent permeability: 28.7 10^-6 cm/s
Compound 4: the middle estimate sits 1.5-fold (0.18 log units) below what was measured, within the range that was stated.
By their numbers in this assay, from the lowest: compounds 2, 3, 1 and 4 (each within the scatter of the next, the first and the last beyond it).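

In this assay, the swap gives this position its first step beyond the scatter, though only a modest one (a 2.1-fold higher number from compound 2 to compound 4 (0.33 log units; beyond the scatter)), so the two ends of the series are now separated: oxan-2-yl in compound 2 and oxetan-2-yl in compound 4. The two remaining steps (a 1.4-fold higher number from compound 3 to compound 4 (0.14 log units; within the scatter) and a 1.1-fold higher number from compound 1 to compound 4 (0.04 log units; within the scatter)) both stay within the scatter, so oxetan-2-yl cannot be told apart from either 1,4-dioxan-2-yl or 3,3-dimethyloxetan-2-yl, and the pair of compound 1 and compound 4 shows no readable effect of the dimethyl substitution on the oxetan ring. No measurement shown here accounts for the one step that clears the scatter.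

The compounds shown all carry an oxygen-containing ring at this place, so it remains open whether an amine, a carboxylic acid or a longer ether chain on the same saturated chain carbon would hold the number near that of compound 4. As far as these compounds go, it is also open whether the separation between oxan-2-yl and oxetan-2-yl would hold on any core other than this one.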